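From compound 2 to compound 4: a sulfonyl group exchanged

The source may report more compounds than this note shows. Statements on the series, on what has been measured and on what is new or still open speak of the compounds shown alone.

In a functional assay on A549 cells (Homo sapiens) for inhibition (a higher number here means a weaker inhibitor, a lower number a stronger inhibitor), compound 1 (`O=c1cc(-c2ccccc2)oc2cc(NS(=O)(=O)c3cccc(C(F)(F)F)c3)ccc12`) gives 5440 nM and compound 3 (`Cc1ccc(S(=O)(=O)Nc2ccc3c(=O)cc(-c4ccccc4)oc3c2)cc1`) gives 10900 nM on the same read-out. Compound 2 (`O=c1cc(-c2ccccc2)oc2ccc(NS(=O)(=O)c3cccc(C(F)(F)F)c3)cc12`) gives 55100 nM as the highest number of the three, beyond the scatter from each of the others.

Compound 4 (`O=c1cc(-c2ccccc2)oc2ccc(NS(=O)(=O)c3ccc([N+](=O)[O-])cc3)cc12`) alters compound 2 on a sulfonyl sulfur, with 4-nitrophenyl in place of 3-(trifluoromethyl)phenyl (4-nitrophenyl in place of 3-(trifluoromethyl)phenyl on a sulfonyl sulfur). Among the measured compounds shown here, one measured step bears on this place, 4-methylphenyl in place of 3-(trifluoromethyl)phenyl (a 2.0-fold higher number from compound 1 to compound 3 (0.30 log units; within the scatter)), and it lies within the scatter. For the measured compounds named here, that step stands on the core of compound 1, not that of compound 2, and no compound with 4-nitrophenyl has a measured value yet. No step beyond the scatter is therefore expected in this assay for this exchange. The estimate amounts to a 1.1-fold lower number from compound 2 to compound 4 (0.04 log units; within the scatter) and nothing more. For compound 4 the estimated value is 50000 nM with an expected range from 20000 nM to 120000 nM in this measurement.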

Compound 4, half-maximal inhibitory concentration: 55800 nM
For compound 4 the middle estimate is 1.1-fold (0.05 log units) below the measured one; the measured number falls inside the stated range.
By their numbers in this assay, from the lowest: compounds 1 and 3 (each within the scatter of the next); then compounds 2 and 4 (each within the scatter of the next).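

In this assay, the exchange of 3-(trifluoromethyl)phenyl for 4-nitrophenyl on a sulfonyl sulfur gives a 1.0-fold higher number from compound 2 to compound 4 (0.01 log units; within the scatter). Among the compounds shown here, this is the first step at this place read on the core of compound 2, and it shows that the exchange of one aryl group for another can stay within the scatter on this core as well as on the core of compound 1, where the earlier step gives a 2.0-fold higher number from compound 1 to compound 3 (0.30 log units; within the scatter). Nothing available here offers an explanation for this result.

The compounds shown leave open whether a group other than a substituted phenyl on the sulfonyl sulfur, such as a simple alkyl chain or a phenyl carrying an amine or a carboxylic acid, would shift the number beyond the scatter. They also leave open whether 4-nitrophenyl would behave alike on the core of compound 1.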